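Methoxy for tert-butyl at the aryl carbon: compound 3

The source may report more compounds than this note shows. Statements on the series, on what has been measured and on what is new or still open speak of the compounds shown alone.

Measured so far in a functional assay on MCF7 cells (Homo sapiens) for antiproliferative activity, read by sulforhodamine B assay, with a stated time of 48 h; a lower number here means a stronger inhibitor of growth, a higher number a weaker inhibitor of growth:
compound 1 `NS(=O)(=O)NCC1CCN(c2cc(-c3ccccc3)ncn2)CC1` 34300 nM
compound 2 `CC(C)(C)c1ccc(-c2cc(N3CCC(CNS(N)(=O)=O)CC3)ncn2)cc1` 19700 nM

Compound 2 gives the lower of the two numbers shown, with compound 1 nearest, but the step of a 1.7-fold lower number from compound 1 to compound 2 (0.24 log units; within the scatter) is within the scatter, so the two are not separated. Compound 3 `COc1ccc(-c2cc(N3CCC(CNS(N)(=O)=O)CC3)ncn2)cc1` differs from compound 2 by methoxy in place of tert-butyl on an aromatic carbon. Among the measured compounds shown here, the only measured step touching that carbon is a 1.7-fold lower number from compound 1 to compound 2 (0.24 log units; within the scatter), which stayed within the scatter, so no step beyond the scatter is expected in this assay; the expected step is a 1.3-fold higher number from compound 2 to compound 3 (0.10 log units; within the scatter). Compound 3 is estimated at 25000 nM, within 10000 nM to 60000 nM.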

Compound 3, concentration for 50% growth inhibition: 35300 nM
Estimate against measurement, compound 3: 1.4-fold (0.15 log units) below, and the stated range covers the measured number.
By their numbers in this assay, from the lowest: compounds 2, 1 and 3 (each within the scatter of the next).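

In this assay, methoxy on this aromatic carbon, para to a large group, gives a 1.8-fold higher number from compound 2 to compound 3 (0.25 log units; within the scatter) and, against hydrogen, a 1.0-fold higher number from compound 1 to compound 3 (0.01 log units; within the scatter), so hydrogen, tert-butyl and methoxy are not separated here. The position has now carried a group with a hydrogen-bond acceptor as well as one without, and no step beyond the scatter has appeared. No measurement at hand bears on this result.

Going by these compounds, whether an amine or a carboxylic acid on this carbon would give a step beyond the scatter stays open. Also open, on these data alone, is whether a change elsewhere on the shared core would do so.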